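The compounds below may be only part of what the source reports. "The series", "measured", "known", "first", "only" and "open" are said of these compounds alone.

Measured in a functional assay on MCF7 cells (Homo sapiens) for cytotoxicity; a higher number here means a weaker inhibitor of growth, a lower number a stronger inhibitor of growth:
- Compound 1 `COc1ccc(NS(=O)(=O)c2c(F)cc(F)c(F)c2F)cc1`: 4500 nM
- Compound 2 `COc1ccc(NS(=O)(=O)c2c(F)c(F)c(Br)c(F)c2F)cc1`: 36000 nM

Of these two compounds, compound 2 has the higher number in this assay, and its gap to compound 1 lies beyond the scatter. It is therefore the weaker growth inhibitor of the pair. The next compound to be tested is compound 3 `COc1ccc(NS(=O)(=O)c2c(F)c(F)c(F)c(F)c2F)cc1`, which carries fluoro in place of bromo on an aromatic carbon, para to a large group: fluoro in place of bromo on an aromatic carbon. For the measured compounds named here, no measured pair shows this swap directly, so the expectation rests on thin ground. Compound 1, at 4500 nM, shows that a number well below that of compound 2 is reachable among these close relatives. A large step towards a lower number, well beyond the scatter, is expected, and it is estimated as a 180-fold lower number from compound 2 to compound 3 (2.26 log units; beyond the scatter). For compound 3 the estimated value is 200 nM, with an expected range from 40 nM to 1500 nM.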

Compound 3, concentration for 50% growth inhibition: 29 nM
For compound 3 the middle estimate is 6.9-fold (0.84 log units) above the measured one; measured number below the stated range.
By their numbers in this assay, from the lowest: compound 3; then compound 1; then compound 2.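

In this assay the place para to a large group turns out to be far more sensitive than the first two compounds could show, with a 1200-fold lower number from compound 2 to compound 3 (3.09 log units; beyond the scatter) when fluoro replaces bromo and a 160-fold lower number from compound 1 to compound 3 (2.19 log units; beyond the scatter) when fluoro replaces hydrogen. Compound 1 and compound 2 showed only that bromo here gives a higher number than hydrogen, whereas compound 3 shows that a halogen at this same place can also give a much lower number than hydrogen, so the outcome depends on which halogen is present. Nothing measured here bears on why fluoro behaves so differently from bromo.

As far as these compounds go, whether chloro, a methoxy group or an amine at this place would follow fluoro, hydrogen or bromo remains open. So does whether the large gain from fluoro would survive if the methoxy group on the other ring were replaced by a hydroxyl group.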